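This account rests on a few compounds, and the source may have more. Where it says the series, first, only, none or still open, it means among the compounds named here.

In a functional assay on HCT-116 cells (Homo sapiens) for inhibition, read by sulforhodamine B assay, with a stated time of 48 h, tested at 50 uM (a higher number here means more inhibition of growth at the concentration tested, a lower number less inhibition of growth), three compounds have been measured:
compound 1 `COc1ccc2c(c1)C(=O)C(=O)N2CCCCCn1cc(COc2cc(=O)oc3ccccc23)nn1` gives 25%;
compound 2 `O=C1C(=O)N(CCCCn2cc(COc3cc(=O)oc4ccccc34)nn2)c2ccc(Cl)cc21` gives 62%;
compound 3 `COc1ccc2c(c1)C(=O)C(=O)N2CCCn1cc(COc2cc(=O)oc3ccccc23)nn1` gives 52%.

Compound 3 stands second highest of these three numbers. The number of compound 2 lies within the usual scatter of that of compound 3, so the two cannot be told apart on this evidence. Compound 1 lies furthest away, with a number lower by more than the scatter.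

Compound 4 `O=C1C(=O)N(CCCn2cc(COc3cc(=O)oc4ccccc34)nn2)c2ccccc21` has not yet been measured. It differs from compound 3 in one place: hydrogen in place of methoxy on an aromatic carbon. Among the compounds with values here, no measured pair shows what this change does on its own, so the expectation rests on compound 3 alone. The step of a number 5 percentage points lower from compound 3 to compound 4 (within the scatter) is expected to stay within the scatter, with no clear direction. Compound 4 is therefore estimated at 47%, within 22% to 70%.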

Compound 4, percent growth inhibition at one concentration: 79%
Compound 4: the middle estimate sits 32 percentage points below what was measured; the measured number lies above the stated range.
By their numbers in this assay, from the lowest: compound 1; then compounds 3 and 2 (each within the scatter of the next); then compound 4.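

In this assay, hydrogen in place of methoxy on this aromatic carbon gives a number 27 percentage points higher from compound 3 to compound 4 (beyond the scatter). Within the data shown here, this is the first single change measured at this place, and it shows that the methoxy group is not needed for growth inhibition in this pair, since the compound without it inhibits more. No measurement here explains why the step goes this way. As far as these compounds go, whether a hydroxyl group or an amine on the same aromatic carbon would give a similar number remains open. So does whether this change acts alike on the longer chain of compound 1.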